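Saturating the Acid Chain of an Unreadable Pair

This account rests on a few compounds, and the source may have more. Where it says the series, first, only, none or still open, it means among the compounds named here.

Measured in a functional assay on MCF7 cells (Homo sapiens) for cytotoxicity, read by MTT assay; on this read-out lower numbers stand for stronger inhibition and higher numbers for weaker inhibition:
- compound 1 `CCOC(=O)C(C)Oc1cc(O)c2c(=O)c(O)c(-c3ccc(OC)cc3)oc2c1CC=C(C)C`: > 100000 nM
- compound 2 `COc1ccc(-c2oc3c(CC=C(C)C)c(OC/C=C/C(=O)O)cc(O)c3c(=O)c2O)cc1`: > 100000 nM

Compound 2 stands at > 100000 nM, which is a limit of the assay and not a number. It has no company among real numbers, since the evidence so far is the limit of > 100000 nM in this assay, at which 2 of the 2 values shown sit.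

Compound 3 `COc1ccc(-c2oc3c(CC=C(C)C)c(OCCCC(=O)O)cc(O)c3c(=O)c2O)cc1` keeps the shared core and alters only the acid chain: 2-carboxyethyl in place of 2-carboxyethenyl on a saturated chain carbon bound to an oxygen on an aromatic ring. Cut one bond further out, 3-carboxyprop-2-en-1-yl becomes 3-carboxypropyl, and the carboxy end stays in both names.

Among the compounds with values here, the only measured step, a step that the two limits leave unreadable from compound 1 to compound 2, also changes the group on that oxygen. Both of its ends are limits, so it offers no size to carry over. What it does show is that two different chains on this oxygen ended at the same limit, and the new change is a small one within a single chain. In this assay the expected step that the limit leaves unreadable from compound 2 to compound 3 is therefore none beyond the scatter, in neither direction. The estimated value for compound 3 is 110000 nM, with an expected range of 50000 nM to 200000 nM, and a further limit is the likeliest report.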

Compound 3, half-maximal inhibitory concentration: > 100000 nM
Compound 3: no number, only a limit; the forecaster's own chance of this, stated with the estimate: 80%; the middle value lies beyond the limit too.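

Compound 3 also ends at a limit of the assay and not at a number, so no step among compound 1, compound 2 and compound 3 can be read: the limit of > 100000 nM in this assay, at which 3 of the 3 values shown sit.

On these data alone, what stays open is how these three compounds compare with one another, and whether any chain on this oxygen would give a real number.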